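Chloro for fluoro on a pyrazolyl enaminone series

This account rests on a few compounds, and the source may have more. Where it says the series, first, only, none or still open, it means among the compounds named here.

On these data alone, the set comprises three measured compounds and one still open. Compound 1 `O=C(/C=C\Nc1ccc(Cl)cc1)c1cn(-c2ccccc2)nc1-c1ccc(F)cc1` and compound 2 `O=C(/C=C\Nc1ccc(Cl)cc1)c1cn(-c2ccccc2)nc1-c1ccc(Cl)cc1` share one core, while compound 3 `COc1cc(-c2nn(-c3ccccc3)cc2C(=O)/C=C\Nc2ccc(F)cc2)cc(OC)c1OC` and compound 4 `COc1cc(-c2nn(-c3ccccc3)cc2C(=O)/C=C\Nc2ccc(Cl)cc2)cc(OC)c1OC` share another; the difference between the two cores is not broken down here. In a functional assay on U-87MG ATCC cells (Homo sapiens) for antiproliferative activity, read by MTT assay, with a stated time of 48 h (a higher number here means a weaker inhibitor, a lower number a stronger inhibitor), compound 1 gives 8900 nM, compound 2 gives 13100 nM and compound 3 gives 4780 nM. Compound 3 and compound 1 lie within the scatter of each other, whereas compound 2 stands beyond it from compound 3.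

Compound 2 differs from compound 1 by chloro in place of fluoro on an aromatic carbon, and this gave a 1.5-fold higher number from compound 1 to compound 2 (0.17 log units; within the scatter). The same change, (chloro in place of fluoro on an aromatic carbon), turns compound 3 into compound 4. Since the step from compound 1 to compound 2 stayed within the scatter, only a small shift is expected for compound 4, and it is estimated as a 1.4-fold higher number from compound 3 to compound 4 (0.13 log units; within the scatter) because of the earlier 1.5-fold higher number from compound 1 to compound 2 (0.17 log units; within the scatter). Compound 4 is therefore expected to give about 6500 nM in this assay, with a likely range from 3000 nM to 14000 nM.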

Compound 4, half-maximal inhibitory concentration: 3210 nM
Compound 4: the middle estimate sits 2.0-fold (0.31 log units) above what was measured, within the range that was stated.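

On the core of compound 3, chloro in place of fluoro on an aromatic carbon gives, in this assay, a 1.5-fold lower number from compound 3 to compound 4 (0.17 log units; within the scatter). Set beside the earlier step on the other core, the two readings cannot be told apart: the same change on two cores in this assay, a 1.5-fold higher number (0.17 log units; within the scatter) from compound 1 to compound 2 and a 1.5-fold lower number (0.17 log units; within the scatter) from compound 3 to compound 4, 2.2-fold (0.34 log units) apart, within the scatter of two such steps. Across these two pairs, the change therefore stays small on both cores, and the opposite directions of the printed steps carry no weight, but this does not show that the change is inert or that its size transfers reliably, since only two pairs are available and the exchange sits on a 4-fluorophenyl group in compound 1 and on a (4-fluorophenyl)amino group in compound 3.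

The compounds shown leave open whether a bromo, a trifluoromethyl, a nitrile or an amine in the same place would move the number beyond the scatter. They also leave open whether the small steps seen with chloro and fluoro would hold on a core carrying a longer chain between the carbonyl and the aromatic amine.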